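Swapping a hydroxymethylcyclopropyl amide for an alanine acid

The source may report more compounds than this note shows. Statements on the series, on what has been measured and on what is new or still open speak of the compounds shown alone.

Among the measured compounds shown here, compound 2 `CCn1c(C(=O)NC2(CO)CC2)ccc1C(CC)(CC)c1ccc(OCS(=O)(=O)c2ccccc2)c(C)c1` is the only compound with a number in a functional assay on PC-3 cells (Homo sapiens) for antiproliferative activity, read by MTT assay, with a stated time of 24 h (on this read-out lower numbers stand for stronger inhibition and higher numbers for weaker inhibition), where compound 2 gives 3560 nM. Compound 1 `CCn1c(C(=O)NCC(=O)OC)ccc1C(CC)(CC)c1ccc(OCS(=O)(=O)c2ccccc2)c(C)c1` reaches only a limit in this assay, > 50000 nM. For the measured compounds named here, the step of an at least 14-fold lower number from compound 1 to compound 2 (1.14 log units; beyond the scatter) is the sole measured change and it involved the same amide-type nitrogen. Compound 3 `CCn1c(C(=O)N[C@H](C)C(=O)O)ccc1C(CC)(CC)c1ccc(OCS(=O)(=O)c2ccccc2)c(C)c1` differs from compound 2 by 1-carboxyethyl in place of 1-(hydroxymethyl)cyclopropyl on an amide-type nitrogen. Going by the values given here, since the one measured step shows that this position moves the read-out strongly, an expected weakening is estimated for compound 3 as a 4.2-fold higher number from compound 2 to compound 3 (0.62 log units; beyond the scatter), giving an estimated 15000 nM for compound 3, between 3000 nM and 60000 nM.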

Compound 3, half-maximal inhibitory concentration: 20100 nM
Compound 3: the middle estimate sits 1.3-fold (0.13 log units) below what was measured; measured number inside the range.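

In this assay, 1-carboxyethyl on the amide-type nitrogen gives a 5.6-fold higher number from compound 2 to compound 3 (0.75 log units; beyond the scatter), so this position responds even to a group with the same heavy-atom count as 1-(hydroxymethyl)cyclopropyl. The same group, in place of (methoxycarbonyl)methyl, gives an at least 2.4-fold lower number from compound 1 to compound 3 (0.39 log units; beyond the scatter), which places compound 3 in the middle of the three. The size of that step stays open-ended, since compound 1 is represented only by a limit: the limit of > 50000 nM in this assay, at which 1 of the 3 values shown sits.

The ring and the hydroxymethyl change together here, so their contributions cannot be separated. A cyclopropyl carrying a carboxylic acid, or an open-chain alcohol, would separate them.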